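Nitrophenyl for methoxyphenyl on two ester cores

The source may hold more compounds than are shown below. What is called first, only, known or untested is meant among the compounds shown, and "the series" means these compounds.

Compounds measured in a functional assay on SK-LU-1 cells (Homo sapiens) for antiproliferative activity, read by sulforhodamine B assay, with a stated time of 48 h, tested at 50 uM; a higher number here means more inhibition at the concentration tested (going by the name of the read-out), a lower number less inhibition:
compound 1, `COc1cccc(C(=O)Oc2cc3c(cc2C)[C@@H](C(C)C)CC=C3C)c1`, gives 24.2%
compound 2, `CC1=CC[C@H](C(C)C)c2cc(C)c(OC(=O)c3ccc([N+](=O)[O-])cc3)cc21`, gives 47.5%
compound 3, `COc1cccc(C(=O)Oc2cc3c(C)ccc(C(C)C)c3cc2C)c1`, gives 30.6%

The three measured compounds share an aryl ester attached to a substituted bicyclic scaffold. Compound 1 and compound 2 have the same core and differ only in the aryl group on the ester: 4-nitrophenyl in place of 3-methoxyphenyl on a carbonyl carbon. This change gives a number 23.3 percentage points higher from compound 1 to compound 2 (beyond the scatter), a step that lies beyond the usual scatter of this assay.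

Compound 3 carries the same 3-methoxyphenyl ester as compound 1 but on a different core; the difference between the two cores is not broken down here. In this assay compound 3 stands within the scatter of compound 1, so the two values cannot be ordered, while compound 2 stands beyond the scatter above both.

Compound 4, `Cc1cc2c(C(C)C)ccc(C)c2cc1OC(=O)c1ccc([N+](=O)[O-])cc1`, has not yet been measured. It is related to compound 3 by the same change that turns compound 1 into compound 2: 4-nitrophenyl in place of 3-methoxyphenyl on a carbonyl carbon. The place of the change is described in the same words in both pairs, so this is the same change applied to a second core.

Among the compounds with values here, because the one measured example of this change gave a number 23.3 percentage points higher from compound 1 to compound 2 (beyond the scatter), a step of similar size is expected from compound 3 to compound 4, namely a number 22.4 percentage points higher from compound 3 to compound 4 (beyond the scatter). That expectation rests on a single pair and on the assumption that the change behaves alike on the core of compound 3. Compound 4 is therefore estimated to give 53% in this assay, with the plausible range running from 38% to 68%.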

Compound 4, a percentage reported as inhibition, at one concentration (the size of the read-out at that concentration, not a potency): 100%
The estimate for compound 4 lay 47 percentage points below the measured number, outside the stated range (above it).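

In this assay, replacing 3-methoxyphenyl with 4-nitrophenyl on a carbonyl carbon on the second core gave a number 69.4 percentage points higher from compound 3 to compound 4 (beyond the scatter). The direction of the step therefore carried over from one core to the other in these two pairs, but its size did not, so the core on which the change is made matters to how much it delivers in this series: the same change on two cores in this assay, a number 23.3 percentage points higher (beyond the scatter) from compound 1 to compound 2 and a number 69.4 percentage points higher (beyond the scatter) from compound 3 to compound 4, 46.1 percentage points apart, beyond the scatter of two such steps

These pairs do not show why the step differs between the cores, and two pairs of single-concentration readings give neither a rule for further cores nor any measure of potency.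

The compounds shown carry only these two aryl groups on the ester, so it remains open how a nitrile or a trifluoromethyl on the phenyl ring, or an amine or a carboxylic acid in place of the nitro group, would behave on either core. As far as these compounds go, it also remains open whether the larger step on the second core would persist with a longer chain in place of the isopropyl group, or with an amide in place of the ester.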